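This account rests on a few compounds, and the source may have more. Where it says the series, first, only, none or still open, it means among the compounds named here.

Measured so far in an ADME assay on HEK293 cells (Homo sapiens) for cytotoxicity, read by MTT assay, with a stated time of 24 h; a higher number here means a weaker inhibitor, a lower number a stronger inhibitor:
- compound 1 `O=C1NC(O)(CCn2cc(C3=CCCCC3)nn2)C(OCc2ccccc2)=C1OCc1ccccc1`: 70000 nM
- compound 2 `CC(C)(C)c1ccc(-c2cn(CCC3(O)NC(=O)C(OCc4ccccc4)=C3OCc3ccccc3)nn2)cc1`: a limit of this assay, > 100000 nM

Compound 1 gives a number in this assay, 70000 nM. For compound 2 this assay reports only a limit and no number, > 100000 nM. For the measured compounds named here, compound 2 therefore stands at the limit of > 100000 nM in this assay, at which 1 of the 2 values shown sits, and the one measured step, an at least 1.4-fold higher number from compound 1 to compound 2 (0.15 log units; that floor lies within the scatter), is a floor rather than a size.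

Compound 3 `Cc1ccc(-c2cn(CCC3(O)NC(=O)C(OCc4ccccc4)=C3OCc3ccccc3)nn2)cc1` differs from compound 2 by methyl in place of tert-butyl on an aromatic carbon. Going by the values given here, the only measured step, an at least 1.4-fold higher number from compound 1 to compound 2 (0.15 log units; that floor lies within the scatter), exchanges the whole group on that aromatic carbon rather than a substituent on the phenyl, and its floor lies within the scatter; it gives no basis for a step of any size in either direction here. Within these two compounds there is no precedent for shortening a substituent on the phenyl. The expectation for the step is therefore none beyond the scatter, a number no higher from compound 2 to compound 3 (the limit leaves the size open). The estimate for compound 3 is 100000 nM, between 45000 nM and 220000 nM, with a fair chance that this assay again reports only the limit.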

Compound 3, half-maximal inhibitory concentration: 45000 nM
Compound 3: the middle estimate sits 2.2-fold (0.35 log units) above what was measured; the measured number falls inside the stated range.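

Methyl in place of tert-butyl on the phenyl gives an at least 2.2-fold lower number from compound 2 to compound 3 (0.34 log units; beyond the scatter) in this assay, the first step in the series that lies beyond the scatter, so a change on the phenyl alone can register in this read-out. Compound 2 is held at a limit and not at a number, which leaves the full size of that step unknown: the limit of > 100000 nM in this assay, at which 1 of the 3 values shown sits.

Exchanging the whole group on the aromatic carbon, by contrast, gives a 1.6-fold lower number from compound 1 to compound 3 (0.19 log units; within the scatter), so 4-methylphenyl and cyclohex-1-en-1-yl are not separated here, and the earlier floor from the same kind of exchange offered no such signal.

As far as these compounds go, two substituents on the phenyl define no trend, and it remains open whether the number would continue to move with a bare hydrogen, an ethyl or isopropyl group of intermediate size, or a different kind of group such as methoxy, an amine or a carboxylic acid at the same place. From the compounds shown here alone, it also remains open whether the same change on the phenyl would carry over if the benzyl ethers on the shared core were replaced.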